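Lengthening the amide chain: compound 3 to compound 4

The source may hold more compounds than are shown below. What is called first, only, known or untested is meant among the compounds shown, and "the series" means these compounds.

In a functional assay on HT-29 cells (Homo sapiens) for antiproliferative activity, read by sulforhodamine B assay, with a stated time of 72 h (a higher number here means a weaker inhibitor, a lower number a stronger inhibitor), compound 1 (`CCCCCCCCc1ccc(CCC(CO)(CO)NC(C)=O)c2ccccc12`) gives 36500 nM, compound 2 (`CCCCCCCCc1ccc(CCC(CO)(CO)NC(=O)CCC)c2ccccc12`) gives 26400 nM and compound 3 (`CCCCCCCCc1ccc(CCC(CO)(CO)NC(=O)CCCCC)c2ccccc12`) gives 20300 nM. Compound 3 is not separated from either of the other two, since its steps to both lie within the scatter.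

Compound 4 (`CCCCCCCCc1ccc(CCC(CO)(CO)NC(=O)CCCCCCC)c2ccccc12`) differs from compound 3 by one change: ethyl in place of hydrogen on a saturated chain carbon, five bonds along the chain from a carbonyl carbon. This is ethyl in place of hydrogen on a saturated chain carbon, five bonds along the chain from a carbonyl carbon.

Two measured steps make the same ethyl addition closer to the carbonyl carbon: a 1.4-fold lower number from compound 1 to compound 2 (0.14 log units; within the scatter) and a 1.3-fold lower number from compound 2 to compound 3 (0.11 log units; within the scatter). The butyl change gives a 1.8-fold lower number from compound 1 to compound 3 (0.25 log units; within the scatter). All three are small and within the scatter, so no step beyond the scatter is expected in this assay. The expected step, a 1.2-fold lower number from compound 3 to compound 4 (0.08 log units; within the scatter), is a slight one towards a lower number and stays within the scatter. For compound 4 the estimated value is 17000 nM, with an expected range of 9000 nM to 32000 nM.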

Compound 4, half-maximal inhibitory concentration: 22000 nM
For compound 4 the middle estimate is 1.3-fold (0.11 log units) below the measured one; measured number inside the range.
By their numbers in this assay, from the lowest: compounds 3, 4, 2 and 1 (each within the scatter of the next).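

In this assay the ethyl addition five bonds along the chain from a carbonyl carbon gives a 1.1-fold higher number from compound 3 to compound 4 (0.03 log units; within the scatter), while the longer changes give a 1.2-fold lower number from compound 2 to compound 4 (0.08 log units; within the scatter) and a 1.7-fold lower number from compound 1 to compound 4 (0.22 log units; within the scatter), so extending the amide chain to this length still produces no step beyond the scatter. The ethyl change reads the same on the core of compound 1 and the core of compound 3: the same change on two cores in this assay, a 1.4-fold lower number (0.14 log units; within the scatter) from compound 1 to compound 2 and a 1.1-fold higher number (0.03 log units; within the scatter) from compound 3 to compound 4, 1.5-fold (0.18 log units) apart, within the scatter of two such steps. The butyl change also reads the same on two cores: the same change on two cores in this assay, a 1.8-fold lower number (0.25 log units; within the scatter) from compound 1 to compound 3 and a 1.2-fold lower number (0.08 log units; within the scatter) from compound 2 to compound 4, 1.5-fold (0.18 log units) apart, within the scatter of two such steps.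

With every step among these four compounds inside the scatter, they do not show that the length of the amide chain matters in this range. On these data alone, a longer chain, or a carboxylic acid or an amine at the end of the amide chain, remains open.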